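The source may hold more compounds than are shown below. What is called first, only, known or untested is meant among the compounds shown, and "the series" means these compounds.

Measured compounds in the series:

- compound 1, `CC[C@H](C)[C@H](NC(=O)c1cccc(Cn2ccnc2)c1)C(=O)NS(=O)(=O)c1ccccc1`, in an assay on HEK293 cells for displacement of a labelled ligand from Type-2 angiotensin II receptor (Homo sapiens), tested at 1 uM (a lower number here means a weaker effect, a higher number a stronger effect of the compound at the concentration tested), gives 5%
- compound 2, `CCCCS(=O)(=O)NNC(=O)[C@@H](NC(=O)c1cccc(Cn2ccnc2)c1)[C@@H](C)CC`, in this assay gives "not determined" (no result reported)
- compound 3, `CCCCCS(=O)(=O)NNC(=O)[C@@H](NC(=O)c1cccc(Cn2ccnc2)c1)[C@@H](C)CC`, in this assay gives "not determined" (no result reported)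

Compound 2 therefore stands nowhere on the numbers: there is no single value for it, and compound 3, its nearest relative in the set, is in the same position. Going by the values given here, the only number available is that of compound 1, which shows a small effect in this assay.

The change from compound 2 to compound 4, `CC[C@H](C)[C@H](NC(=O)c1cccc(Cn2ccnc2)c1)C(=O)NNS(=O)(=O)c1ccc(C)cc1`, is 4-methylphenyl in place of butyl on a sulfonyl sulfur. Among the compounds with values here, no step between measured compounds is known for this or any related change, so the size of the step in this assay cannot be taken from the data; the expectation is that it stays within the usual scatter, with no clear direction. What is expected for compound 4 rests on compound 1 alone, whose 5% is the one anchor in the set, and on the absence of any number for compound 2 or compound 3.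

Compound 4 is expected to give about 10% in this assay, with a range from 0% to 35%.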

Compound 4, a percentage reported as inhibition, at one concentration (the size of the read-out at that concentration, not a potency): 4%
Compound 4: middle estimate off by 6 percentage points, on the high side, and the stated range covers the measured number.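

Putting ((4-methylphenyl)sulfonyl)amino in place of phenylsulfonyl on an amide-type nitrogen gives a number 1 percentage points lower from compound 1 to compound 4 (within the scatter) in this assay, so compound 1 at 5% and compound 4 at 4% cannot be told apart. Going by these compounds alone, this gives the series its only readable step and a second number for a compound with an aromatic ring on the sulfonyl sulfur, but the step combines the added amino nitrogen with the methyl of 4-methylphenyl, and the two contributions cannot be separated here. No supporting measurement bears on why the read-out stays within the scatter across this change.

The steps involving compound 2 and compound 3 cannot be read, which leaves butyl against 4-methylphenyl on the sulfonyl sulfur, and any effect of chain length in the sulfonyl group, unsettled. Also open, on these data alone, is whether a different group on the sulfonyl sulfur, such as a phenyl ring carrying a carboxylic acid or an amine, or a chain longer than pentyl, would move the read-out in this assay beyond the scatter.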